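From amino to methyl, close to the assay's limit

The compounds below may be only part of what the source reports. "The series", "measured", "known", "first", "only" and "open" are said of these compounds alone.

Measured in a functional assay on HL-60 cells (Homo sapiens) for cytotoxicity, read by MTT assay, with a stated time of 48 h; a lower number here means a stronger inhibitor, a higher number a weaker inhibitor:
Compound 1 `Fc1cccc(-c2nc(Nc3ccc(Br)cc3)c3cc(F)ccc3n2)c1`: > 50000 nM
Compound 2 `Oc1cccc(Nc2nc(-c3cccc(F)c3)nc3ccc(F)cc23)c1`: > 50000 nM
Compound 3 `Nc1ccccc1Nc1nc(-c2cccc(F)c2)nc2ccc(F)cc12`: 41300 nM

Compound 3 is the only one of these with a real number. The other two entries are limits of the assay and not numbers: the data show (the limit of > 50000 nM in this assay, at which 2 of the 3 values shown sit).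

Compound 4 `Cc1ccccc1Nc1nc(-c2cccc(F)c2)nc2ccc(F)cc12` differs from compound 3 in one place, with methyl in place of amino on an aromatic carbon, ortho to a large group (methyl in place of amino on an aromatic carbon).

Among the measured compounds shown here, two measured steps bear on this change, as both alter the group on the same nitrogen: an at least 1.2-fold lower number from compound 1 to compound 3 (0.08 log units; that floor lies within the scatter) and an at least 1.2-fold lower number from compound 2 to compound 3 (0.08 log units; that floor lies within the scatter). Both are floors rather than exact sizes, and neither goes beyond the scatter. A third step, a step that the two limits leave unreadable from compound 1 to compound 2, gives no usable size. None of the three swaps amino for methyl, so the evidence is indirect.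

In this assay no step beyond the scatter is therefore expected, and compound 4 may well return only a limit. The estimated step is a 1.0-fold lower number from compound 3 to compound 4 (0.01 log units; within the scatter) in the expected case of a real number. For compound 4 the estimate is 40000 nM, with a range from 15000 nM to 80000 nM expected.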

Compound 4, half-maximal inhibitory concentration: > 50000 nM
Compound 4 was reported as a limit; the forecaster's own chance of this, stated with the estimate: 50%; middle value at least 1.2-fold (0.09 log units) away from the limit.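

In this assay, among the compounds shown here, methyl in place of amino on this aromatic carbon gives an at least 1.2-fold higher number from compound 3 to compound 4 (0.08 log units; that floor lies within the scatter), the first direct reading of this change, which the earlier steps could only approach indirectly. The entry for compound 4 is a limit of the assay and not a number, so this step has only a floor, and nothing printed carries it beyond the scatter; with methyl in this place, the compound does not return a real number, which leaves compound 3 as the only one of the four that does. The steps to compound 4 from compound 1 and from compound 2 cannot be read because both ends of each are limits: the limit of > 50000 nM in this assay, at which 3 of the 4 values shown sit.

Going by these compounds, it remains open whether amino itself matters here or whether compound 3 merely falls just inside the range the assay can read. A methoxy group, a carboxylic acid or an aminomethyl group on the same aromatic carbon could show whether any group in this place gives a number clearly apart from that of compound 3.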